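Replacing 2-methoxyphenyl with 4-bromophenyl in compound 1

A few compounds are considered here, and "the series" means these few. Any claim that something is new, unique, unknown or untested is made for them only; others in the source may bear on it.

Values measured in a functional assay on the whole organism (strain Kunming) with Mus musculus as the target, with a stated time of 0.5 h; a lower number here means that less compound is needed, a higher number that more compound is needed for the effect:
compound 1 `COc1ccccc1/C=C/C(=O)OC/C=C/c1cc(OC)c(OC)cc1OC`: 240 mg/kg
compound 2 `COc1cc(OC)c(OC)cc1/C=C/COC(=O)/C=C/c1c(OC)ccc(OC)c1OC`: 212 mg/kg
compound 3 `COc1cc(OC)c(OC)cc1/C=C/COC(=O)/C=C/c1cc(OC)c(OC)c(OC)c1OC`: 155 mg/kg

In this assay, compound 1 stands at 240 mg/kg. This value lies within the usual scatter of the other two, so the numbers do not separate compound 1 from compound 2 or from compound 3. The measured set therefore forms a single narrow group, and no ranking can be drawn from it.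

The next compound to be tested is compound 4 `COc1cc(OC)c(OC)cc1/C=C/COC(=O)/C=C/c1ccc(Br)cc1`, which has no measured value yet. It departs from compound 1 by one change: 4-bromophenyl in place of 2-methoxyphenyl on a double-bonded chain carbon bound to a double-bonded chain carbon. In words, 4-bromophenyl stands in place of 2-methoxyphenyl on a double-bonded chain carbon bound to a double-bonded chain carbon.

For the measured compounds named here, no step between measured compounds is available to size this change directly, and none of the three measured compounds carries 4-bromophenyl. The expectation therefore rests only on how closely the measured values sit, with compound 2 at 212 mg/kg and compound 3 at 155 mg/kg. No step beyond the scatter is expected, in either direction. The estimated step is a 1.2-fold lower number from compound 1 to compound 4 (0.08 log units; within the scatter). Compound 4 is expected at 200 mg/kg, with an estimated range of 110 mg/kg to 360 mg/kg.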

Compound 4, dose for half-maximal effect: 193 mg/kg
For compound 4 the middle estimate is 1.0-fold (0.02 log units) above the measured one; the range from low to high includes it.
By their numbers in this assay, from the lowest: compounds 3, 4, 2 and 1 (each within the scatter of the next).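

In this assay, 4-bromophenyl in place of 2-methoxyphenyl on a double-bonded chain carbon bound to a double-bonded chain carbon gives a 1.2-fold lower number from compound 1 to compound 4 (0.09 log units; within the scatter). For the compounds shown here, this is the first step in the set that isolates a single place, and it shows that the two groups cannot be told apart at this position by this read-out. The group that leaves carries 1 hydrogen-bond acceptor and the group that enters carries 0, with bromine in place of the oxygen-bearing substituent, yet this pair shows no step beyond the scatter, and nothing available explains why the two groups read alike.

The compounds shown leave open whether this flat reading extends to groups of another kind at this place, such as a phenyl ring carrying an amine or a carboxylic acid, or to a simpler neighbour of bromine such as 4-chlorophenyl. They also leave open whether the same swap would read alike on a differently substituted version of the core of compound 1, as a single pair cannot establish a general rule for this position.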